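This account rests on a few compounds, and the source may have more. Where it says the series, first, only, none or still open, it means among the compounds named here.

Compound 1 `CCCCN(O)C(=O)Nc1cc([C@@H]2CC[C@@H](c3cc(OC)c(OC)c(OC)c3)O2)cc(OC)c1OCCSc1ccc(Cl)cc1` gives 20 nM in an assay for displacement of a labelled ligand from platelet-activating factor receptor (Homo sapiens); a higher number here means a weaker inhibitor, a lower number a stronger inhibitor. Compound 3 `CCCCN(O)C(=O)NCc1cc([C@@H]2CC[C@@H](c3cc(OC)c(OC)c(OC)c3)O2)cc(OC)c1OCCSc1ccc(Cl)cc1` gives 167 nM in this assay, and the step of an 8.4-fold higher number from compound 1 to compound 3 (0.92 log units; beyond the scatter) concerns the attachment of the butyl(hydroxy)carbamoyl group to the core, not the aryl sulfur group. Compound 2 `CCCCN(O)C(=O)Nc1cc([C@@H]2CC[C@@H](c3cc(OC)c(OC)c(OC)c3)O2)cc(OC)c1OCCS(=O)(=O)c1c(F)c(F)cc(F)c1F` gives 285 nM in this assay, the highest of the three numbers; it lies within the scatter of compound 3 and beyond the scatter relative to compound 1. Compound 4 `CCCCN(O)C(=O)Nc1cc([C@@H]2CC[C@@H](c3cc(OC)c(OC)c(OC)c3)O2)cc(OC)c1OCCS(=O)(=O)c1ccc(Br)cc1` carries 4-bromophenyl in place of 2,3,5,6-tetrafluorophenyl on a sulfonyl sulfur. Within the data shown here, no measured step bears directly on this change: compound 1 and compound 2 differ in two places at once, so their values show only the combined outcome, and the single measured step touches a different part of the molecule. The size of the move is therefore uncertain; a modest shift toward a lower number is expected, a 3.2-fold lower number from compound 2 to compound 4 (0.50 log units; beyond the scatter). Compound 4 is expected to give 90 nM in this assay, with a range from 25 nM to 320 nM.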

Compound 4, half-maximal inhibitory concentration: 38 nM
For compound 4 the middle estimate is 2.4-fold (0.37 log units) above the measured one; the measured number falls inside the stated range.
By their numbers in this assay, from the lowest: compounds 1 and 4 (each within the scatter of the next); then compounds 3 and 2 (each within the scatter of the next).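

Among these compounds, on the sulfonyl sulfur, 4-bromophenyl in place of 2,3,5,6-tetrafluorophenyl gives a 7.5-fold lower number from compound 2 to compound 4 (0.88 log units; beyond the scatter) in this assay and so shows that the aryl group on this sulfur alone moves the number beyond the scatter, which the earlier compounds could not separate from the change at the sulfur itself. Putting (4-bromophenyl)sulfonyl in place of (4-chlorophenyl)sulfanyl on the saturated chain carbon gives a 1.9-fold higher number from compound 1 to compound 4 (0.28 log units; within the scatter) and so leaves these two compounds indistinguishable here, showing that a sulfonyl-linked aryl group can match the sulfanyl-linked one. No evidence is available to explain either result. Going by these compounds, what a plain phenyl or a pyridine ring would give on the sulfonyl sulfur stays open. So does whether the step from the tetrafluorophenyl group depends on the bromine or on the loss of the fluorines.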